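The source may report more compounds than this note shows. Statements on the series, on what has been measured and on what is new or still open speak of the compounds shown alone.

Within the data shown here, compound 1 `O=C(NO)c1ccc(/C=C/c2ccnc(-c3cccc(O)c3)c2)cc1` gives 19 nM in an assay on isolated protein for inhibition of protein deacetylase HDAC6 (Homo sapiens), read by fluorescence, with a stated time of 15 min (on this read-out lower numbers stand for stronger inhibition and higher numbers for weaker inhibition), the lowest of the two numbers measured so far; its nearest neighbour, compound 2 `Cc1ccc(-c2cc(/C=C/c3ccc(C(=O)NO)cc3)ccn2)cc1`, gives 150 nM in this assay. Among the measured compounds shown here, the single measured step, a 7.9-fold higher number from compound 1 to compound 2 (0.90 log units; beyond the scatter), is a modest one. Compound 3 `Cc1ccc(-c2cc(/C=C/c3ccc(C(=O)NO)cc3)ccn2)c(F)c1` carries 2-fluoro-4-methylphenyl in place of 3-hydroxyphenyl on an aromatic carbon, on an aromatic carbon of a six-membered aromatic ring with 1 nitrogen, next to the ring nitrogen. The step from compound 1 to compound 2 bears directly on this change: compound 3 keeps the 4-methylphenyl of compound 2 and differs from it by an added fluorine. A weakening of about the same size as that measured step, in the direction of higher numbers, is therefore expected. The expected step is a 7.9-fold higher number from compound 1 to compound 3 (0.90 log units; beyond the scatter) in this assay. The estimate for compound 3 is 150 nM, with a range from 60 nM to 400 nM.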

Compound 3, half-maximal inhibitory concentration: 15 nM
Compound 3: middle estimate off by 10-fold (1.00 log units), on the high side; the whole stated range lies above it.
By their numbers in this assay, from the lowest: compounds 3 and 1 (each within the scatter of the next); then compound 2.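

The one added fluorine of the 2-fluoro-4-methylphenyl group accounts for a 10-fold lower number from compound 2 to compound 3 (1.00 log units; beyond the scatter) in this assay and so has a large effect at this position, which the 4-methylphenyl group of compound 2 alone gave no sign of. With that fluorine in place, the exchange of the 3-hydroxyphenyl group gives a 1.3-fold lower number from compound 1 to compound 3 (0.10 log units; within the scatter) and so shows that a group with 0 hydrogen-bond donors and 0 hydrogen-bond acceptors can stand here in place of the 3-hydroxyphenyl group without a change beyond the scatter.

Going by these compounds, whether the fluorine would have the same effect on the 3-hydroxyphenyl group of compound 1, and whether a chloro, methoxy or amino group could take its place on the 4-methylphenyl ring, remains open. Nothing available here accounts for the size of the fluorine step.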